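Two inverted stereocentres on a dimeric lactone core

The source may report more compounds than this note shows. Statements on the series, on what has been measured and on what is new or still open speak of the compounds shown alone.

Three compounds are compared in a functional assay on CCRF-CEM cells (Homo sapiens) for cytotoxicity; a lower number here means a stronger inhibitor, a higher number a weaker inhibitor. Compound 1 `C=C1C(=O)O[C@H]2CC(C)[C@@]34C[C@@H](C=C3C[C@H]12)[C@@]1(C4)C(=O)O[C@H]2CC(=C)[C@H]3CC[C@@](C)(O)[C@@H]3C[C@@H]21` gives 2030 nM, and compound 3 `C=C1C(=O)O[C@H]2C[C@H](C)C3=C(C[C@H]12)[C@@]1(C)C[C@@H]3C[C@@]12C(=O)O[C@H]1C=C(C)[C@H]3CC[C@@](C)(O)[C@@H]3C[C@@H]12` gives 2030 nM. Compound 2 `C=C1C(=O)O[C@H]2C[C@H](C)C3=C(C[C@H]12)[C@@]1(C)C[C@H]3C[C@@]12C(=O)O[C@@H]1C[C@@]3(C)[C@@H](O)C[C@@H](O)C(=C)[C@@H]3C[C@@H]12` gives 140 nM, the lowest number of the three; the other two sit far enough away that the gaps lie beyond the scatter. Compound 4 `C=C1C(=O)O[C@H]2C[C@H](C)C3=C(C[C@H]12)[C@]1(C)C[C@@H]3C[C@@]12C(=O)O[C@@H]1C[C@@]3(C)[C@@H](O)C[C@@H](O)C(=C)[C@@H]3C[C@@H]12` has not been measured. Compared with compound 2, (the two compounds have the same atoms and bonds and differ only in configuration as drawn: 2 of 12 stereo elements differ; a stereocentre at a saturated ring carbon is drawn R in compound 2 and S in compound 4; a stereocentre at a saturated ring carbon is drawn S in compound 2 and R in compound 4). Among the measured compounds shown here, no measured pair shows what such a flip in configuration does here. Given that compound 2 gives 140 nM, a modest loss of potency, of a size the expected step from compound 2 to compound 4 of a 2.5-fold higher number from compound 2 to compound 4 (0.40 log units; beyond the scatter) expresses, seems most likely. Compound 4 is expected to give about 350 nM, within 90 nM to 1500 nM.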

Compound 4, half-maximal inhibitory concentration: 140 nM
Estimate against measurement, compound 4: 2.5-fold (0.40 log units) above; low and high end bracket the measured number.
By their numbers in this assay, from the lowest: compounds 2 and 4 (each within the scatter of the next); then compounds 1 and 3 (each within the scatter of the next).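

In this assay, inverting the two saturated ring stereocentres brings no change at the digits printed from compound 2 to compound 4 (within the scatter). Among the compounds shown here, this is the first pair here that can be read as a single comparison, and the change in it is purely one of configuration: the fact that compounds 2 and 4 differ only in the configuration as drawn. So the number does not depend on how these two stereocentres are drawn, at least when both are inverted together.

From the compounds shown here alone, whether inverting either stereocentre alone would do the same remains open. So does what an added group, such as an amine, would do on the shared core.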